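Swapping one ring on a sulfonamide nitrogen

The compounds below may be only part of what the source reports. "The series", "measured", "known", "first", "only" and "open" are said of these compounds alone.

Measured in a functional assay on NCI-H460 cells (Homo sapiens) for antiproliferative activity, read by sulforhodamine B assay, with a stated time of 72 h (a lower number here means a stronger inhibitor, a higher number a weaker inhibitor), so far
- Compound 1 `Cc1cc(C)nc(NS(=O)(=O)c2ccc(Nc3nncc4ccccc34)cc2)n1` gives 0.8 nM
- Compound 2 `S=C(NNc1nncc2ccccc12)Nc1ccccc1` gives 16 nM
- Compound 3 `Clc1ccc(C(/C=C/c2ccccc2)=N\Nc2nncc3ccccc23)cc1` gives 9.6 nM

In this assay compound 1 has the lowest number of the three, and its gaps to compound 3 and compound 2 both lie beyond the scatter. Compound 4 `O=S(=O)(Nc1nccs1)c1ccc(Nc2nncc3ccccc23)cc1` has not yet been measured. The change from compound 1 is 1,3-thiazol-2-yl in place of 4,6-dimethylpyrimidin-2-yl on a sulfonamide nitrogen, with 1,3-thiazol-2-yl in place of 4,6-dimethylpyrimidin-2-yl on a sulfonamide nitrogen. Going by the values given here, no measured pair shows this change on its own. Compound 1 at 0.8 nM sits at the low end of the series, so a higher number seems more likely than a lower one. The expected step is a 3.1-fold higher number from compound 1 to compound 4 (0.49 log units; beyond the scatter), a modest loss. The estimated value for compound 4 is 2.5 nM with a range from 0.6 nM to 10 nM until a measurement is available.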

Compound 4, half-maximal inhibitory concentration: 39 nM
Estimate against measurement, compound 4: 16-fold (1.19 log units) below, and the stated range ends below it.
By their numbers in this assay, from the lowest: compound 1; then compounds 3 and 2 (each within the scatter of the next); then compound 4.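

In this assay the group on the sulfonamide nitrogen proves to be a sensitive point: 1,3-thiazol-2-yl in place of 4,6-dimethylpyrimidin-2-yl, with the rest of the molecule unchanged, gives a large loss (a 49-fold higher number from compound 1 to compound 4 (1.69 log units; beyond the scatter)). The earlier compounds shown here differ from compound 1 in more than one place and could not isolate this position. No available evidence accounts for the size of this step.

The change replaces the ring and removes both methyl groups at once, so the compounds shown do not separate these two differences. On these data alone, how an unsubstituted pyrimidin-2-yl or a phenyl group on this nitrogen would compare remains open.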